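The compounds below may be only part of what the source reports. "The series", "measured", "known", "first", "only" and "open" are said of these compounds alone.

Measured compounds:
compound 1, `N#CN/C(=N\CCNc1ccc(N=[N+]=[N-])cc1[N+](=O)[O-])NCCCOc1cccc(CN2CCCCC2)c1`, with 7.39 in a functional assay on cardiac atrium for antagonist activity at histamine H2 receptor (Cavia porcellus); a higher number here means a more potent compound, by a factor of ten per unit of this negative logarithm, a lower number a less potent compound;
compound 2, `N#CN/C(=N\CCNC(=O)c1ccc(N=[N+]=[N-])cc1)NCCCOc1cccc(CN2CCCCC2)c1`, with 7.9 in this assay.

Compound 2 stands highest of the two numbers; its nearest neighbour is compound 1, and the step of a number 0.51 log units higher from compound 1 to compound 2 (beyond the scatter) lies beyond the scatter. That single step exchanges the group on the amine nitrogen and brings in the carbonyl that compound 2 carries.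

Compound 3, `N#CN/C(=N\CCNC(=O)c1ccncc1)NCCCOc1cccc(CN2CCCCC2)c1`, keeps that carbonyl and the rest of the shared core. The change is pyridin-4-yl in place of 4-azidophenyl on a carbonyl carbon. Within the data shown here, the only measured step, from compound 1 to compound 2, alters a different part of the molecule and does not replace one aromatic group on the carbonyl carbon by another, so it bears on compound 3 only loosely: it shows that the region attached to the amine nitrogen tolerates variation while potency stays in a narrow band. Among the measured compounds shown here, with no step of the same kind to lean on, no movement beyond the scatter is expected in this assay.

Compound 3 is therefore estimated at 7.7, between 7.1 and 8.3, an expected step of a number 0.20 log units lower from compound 2 to compound 3 (within the scatter).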

Compound 3, negative logarithm of the antagonist equilibrium constant: 6.89
Estimate against measurement, compound 3: 0.81 log units above, and the stated range ends above it.
By their numbers in this assay, from the lowest: compound 3; then compound 1; then compound 2.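

The group on the carbonyl carbon proves to be far from neutral in this assay: pyridin-4-yl in place of 4-azidophenyl gives a number 1.01 log units lower from compound 2 to compound 3 (beyond the scatter) and is the largest step among the three compounds. The earlier comparison had suggested a narrow band of potency, but this change takes the series out of it, and the exchange of the whole (pyridin-4-yl)carbonyl for 4-azido-2-nitrophenyl on the amine nitrogen also gives a number 0.50 log units lower from compound 1 to compound 3 (beyond the scatter) so that compound 3 ends as the lowest of the three, with both of its steps beyond the scatter. Nothing available explains this loss of potency.

The step from 4-azidophenyl to pyridin-4-yl changes the ring and removes the azide at once, so the compounds shown cannot say which of the two carries the difference. A plain phenyl on the carbonyl carbon would separate the two, and pyridin-3-yl or 4-aminophenyl in the same place would show how far the result depends on the exact group.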